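This account rests on a few compounds, and the source may have more. Where it says the series, first, only, none or still open, it means among the compounds named here.

Measured compounds:
compound 1, `COc1cc2c(Oc3ccc(NC(=O)N/N=C/c4ccc(C(F)(F)F)cc4)cc3F)ccnc2cc1OCCCN1CCCC1`, 1800 nM
compound 2, `COc1ccc(/C=N/NC(=O)Nc2ccc(Oc3ccnc4cc(OCCCN5CCC(C)CC5)c(OC)cc34)c(F)c2)cc1`, 1000 nM
compound 3, `COc1cc2c(Oc3ccc(NC(=O)N/N=C/c4ccc([N+](=O)[O-])cc4)cc3F)ccnc2cc1OCCCN1CCC(C)CC1`, 870 nM

All three share one core and differ only in the group on the outer aromatic ring and in the amine at the end of the chain. In a functional assay on MDA-MB-231 cells (Homo sapiens) for cytotoxicity, read by MTT assay, with a stated time of 72 h (a lower number here means a stronger inhibitor, a higher number a weaker inhibitor), compound 3 gives 870 nM, the lowest of the three numbers; its nearest neighbour is compound 2, within the scatter, and the furthest is compound 1, beyond it.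

Compound 4, `COc1cc2c(Oc3ccc(NC(=O)N/N=C/c4ccc(C(F)(F)F)cc4)cc3F)ccnc2cc1OCCCN1CCC(C)CC1`, has not been measured. It differs from compound 3 in one place: trifluoromethyl in place of nitro on an aromatic carbon. For the measured compounds named here, no measured pair shows exactly this exchange. Going by the values given here, the only single-point step on record, a 1.1-fold lower number from compound 2 to compound 3 (0.06 log units; within the scatter), shows that the nitro and methoxy groups at this site give numbers within the scatter of each other. Compound 1 also carries the trifluoromethyl group, but it differs from compound 3 in the amine as well; in this assay compound 1 gives 1800 nM, which can only hint that the trifluoromethyl variant may sit somewhat higher. Compound 4 is therefore expected to land near compound 3, with a step of a 1.5-fold higher number from compound 3 to compound 4 (0.17 log units; within the scatter), a value of 1300 nM estimated within 500 nM to 3500 nM.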

Compound 4, half-maximal inhibitory concentration: 1300 nM
Compound 4: middle estimate and measured number agree at the digits printed; the range from low to high includes it.
By their numbers in this assay, from the lowest: compounds 3, 2, 4 and 1 (each within the scatter of the next, the first and the last beyond it).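

With the 4-methylpiperidin-1-yl amine held fixed, the aromatic carbon para to a large group now carries three different groups in this assay and the numbers do not separate: the exchange of nitro for trifluoromethyl is a 1.5-fold higher number from compound 3 to compound 4 (0.17 log units; within the scatter) and the exchange of methoxy for trifluoromethyl is a 1.3-fold higher number from compound 2 to compound 4 (0.11 log units; within the scatter) with both steps lying within the scatter. For the compounds shown here, compound 4 also gives the first reading of the amine on its own, as the exchange of pyrrolidin-1-yl for 4-methylpiperidin-1-yl with trifluoromethyl in place is a 1.4-fold lower number from compound 1 to compound 4 (0.14 log units; within the scatter) and this step also lies within the scatter. Neither site, in these single exchanges, moves the number beyond the scatter, and no measurement shown here accounts for any of these numbers.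

From the compounds shown here alone, the amine exchange can be read only with trifluoromethyl on the outer ring, so whether it behaves alike with nitro or methoxy stays open. Going by these compounds, whether a carboxylic acid or a primary amine on that aromatic carbon, or a morpholine at the end of the chain, would give a number beyond the scatter also stays open.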